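Replacing the amide tail of compound 2 with 3-methylpiperidin-1-yl

The compounds below may be only part of what the source reports. "The series", "measured", "known", "first", "only" and "open" are said of these compounds alone.

Compound 2 `CC(C)(C)OC(=O)NCCNC(=O)CN1CN(c2ccccc2)C2(CCN(C(=O)c3ccc(C4CCCCC4)cc3)CC2)C1=O` stands lowest of the two numbers in an assay on HEK293 cells for displacement of a labelled ligand from NPC1-like intracellular cholesterol transporter 1 (Homo sapiens) (a higher number here means a weaker inhibitor, a lower number a stronger inhibitor), where compound 2 gives 5500 nM; compound 1 `COC(=O)CCNC(=O)CN1CN(c2ccccc2)C2(CCN(C(=O)c3ccc(C4CCCCC4)cc3)CC2)C1=O` gives 12900 nM. Compound 3 `CC1CCCN(C(=O)CN2CN(c3ccccc3)C3(CCN(C(=O)c4ccc(C5CCCCC5)cc4)CC3)C2=O)C1` differs from compound 2 as follows: 3-methylpiperidin-1-yl in place of (2-((tert-butoxycarbonyl)amino)ethyl)amino on a carbonyl carbon. Going by the values given here, the only measured step, a 2.3-fold lower number from compound 1 to compound 2 (0.37 log units; beyond the scatter), alters the very group that compound 3 replaces as a whole, and it was modest, so the new tail offers little guidance. Compound 3 is therefore expected to land close to compound 2, with a 1.1-fold lower number from compound 2 to compound 3 (0.04 log units; within the scatter) as the estimated step, giving an expected 5000 nM in this assay with a range of 1800 nM to 14000 nM.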

Compound 3, half-maximal inhibitory concentration: 3600 nM
Estimate against measurement, compound 3: 1.4-fold (0.14 log units) above; the measured number falls inside the stated range.
By their numbers in this assay, from the lowest: compounds 3 and 2 (each within the scatter of the next); then compound 1.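

In this assay, the change on the carbonyl carbon gives a 1.5-fold lower number from compound 2 to compound 3 (0.18 log units; within the scatter), so a tail with one six-membered non-aromatic ring and no hydrogen-bond donors or acceptors reads level with the open-chain (2-((tert-butoxycarbonyl)amino)ethyl)amino tail. The hydrogen-bond donors and acceptors of that chain are therefore not needed to hold this level at this position. Against the other open-chain tail, the same ring gives a 3.6-fold lower number from compound 1 to compound 3 (0.55 log units; beyond the scatter), a modest step.

On these data alone, whether plain piperidine, morpholine or a free primary amine on this carbonyl carbon would shift the number remains open. No available evidence explains the differences seen among these tails.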